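Replacing propylcarbamoyl: from compound 3 to compound 4

A few compounds are considered here, and "the series" means these few. Any claim that something is new, unique, unknown or untested is made for them only; others in the source may bear on it.

In a functional assay on MIA PaCa-2 cells (Homo sapiens) for antiproliferative activity (a lower number here means that less compound is needed, a higher number that more compound is needed for the effect), compound 3 `CCCNC(=O)c1cccc2c1cc(C)n2-c1nc2c(c(NCc3ccccc3)n1)CCCC2` gives 608 nM. Compound 2 `CC#CCNC(=O)c1cccc2c1cc(C)n2-c1nc2c(c(NCc3ccccc3)n1)CCCC2` gives 723 nM, within the scatter of compound 3, as a 1.2-fold lower number from compound 2 to compound 3 (0.08 log units; within the scatter) shows. Compound 1 `C#CCCNC(=O)c1cccc2c1cc(C)n2-c1nc2c(c(NCc3ccccc3)n1)CCCC2` gives 1410 nM. Two steps lead away from it: a 2.3-fold lower number from compound 1 to compound 3 (0.37 log units; beyond the scatter), modest but beyond the scatter, and a 2.0-fold lower number from compound 1 to compound 2 (0.29 log units; within the scatter), within the scatter.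

The next structure is compound 4 `CCC#CC(=O)Nc1cccc2c1cc(C)n2-c1nc2c(c(NCc3ccccc3)n1)CCCC2`. The change is a group of 7 heavy atoms (5 carbon, 1 nitrogen, 1 oxygen; no ring) in place of a group of 6 heavy atoms (4 carbon, 1 nitrogen, 1 oxygen; no ring), on an aromatic carbon: propylcarbamoyl leaves, and the entering group carries a triple bond outside aromatic rings. The site is an aromatic carbon of the six-membered aromatic ring of carbon only.

All three measured steps alter only the chain within the carbamoyl group, so none tests a replacement of the whole group. They offer only a rough scale. The triple-bond-bearing compound 1 at 1410 nM and compound 2 at 723 nM do not fall beyond the scatter on the low side of compound 3, and neither suggests a gain. A modest rise in the number is therefore expected in this assay, of about the size of a 2.3-fold lower number from compound 1 to compound 3 (0.37 log units; beyond the scatter) but in the opposite direction, with low confidence. The expected change is a 2.1-fold higher number from compound 3 to compound 4 (0.33 log units; beyond the scatter). For compound 4 the estimated value is 1300 nM, with an expected range of 350 nM to 4500 nM.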

Compound 4, half-maximal effective concentration: 463 nM
Compound 4: the middle estimate sits 2.8-fold (0.45 log units) above what was measured, and the stated range covers the measured number.
By their numbers in this assay, from the lowest: compounds 4, 3, 2 and 1 (each within the scatter of the next, the first and the last beyond it).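

Replacing the whole propylcarbamoyl group on this aromatic carbon, rather than only its chain, leaves the number in this assay within the scatter (a 1.3-fold lower number from compound 3 to compound 4 (0.12 log units; within the scatter)), and the entering group's triple bond outside aromatic rings does not separate it from the other close comparison either (a 1.6-fold lower number from compound 2 to compound 4 (0.19 log units; within the scatter)). Only the comparison with the terminal alkyne amide goes beyond the scatter, and modestly (a 3.0-fold lower number from compound 1 to compound 4 (0.48 log units; beyond the scatter)), so the triple bond alone does not go with a higher number across the three compounds that carry one. The data hold no measurement that accounts for these differences.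

The entering group differs from propylcarbamoyl both in the direction of its amide and in its triple bond, so a saturated butanoylamino group would be needed to tell those two changes apart. On these data alone, how far this aromatic carbon accepts other kinds of group also remains open, for instance a primary amine, a carboxylic acid, or a longer chain beyond the triple bond.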